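From pyridin-3-yl to thiophen-2-yl on a shared core

The source may report more compounds than this note shows. Statements on the series, on what has been measured and on what is new or still open speak of the compounds shown alone.

Measured in a functional assay on ileum (Cavia porcellus) for inhibition; a lower number here means a stronger inhibitor, a higher number a weaker inhibitor:
Compound 1 `COC(=O)C1=C(C)NC(C)=C(C(=O)OC)C1c1c(-c2cccnc2)nc2sc(C)cn12`: 16000 nM
Compound 2 `COC(=O)C1=C(C)NC(C)=C(C(=O)OC)C1c1c(-c2c(Cl)csc2Cl)nc2sc(C)cn12`: 3230 nM
Compound 3 `COC(=O)C1=C(C)NC(C)=C(C(=O)OC)C1c1c(-c2ccccn2)nc2sc(C)cn12`: 2810 nM

Of these three, compound 1 has the highest number, 16000 nM. Compound 4 `COC(=O)C1=C(C)NC(C)=C(C(=O)OC)C1c1c(-c2cccs2)nc2sc(C)cn12` is still unmeasured and differs from compound 1 as follows: thiophen-2-yl in place of pyridin-3-yl on an aromatic carbon. Thiophen-2-yl thus takes the place of pyridin-3-yl on an aromatic carbon. Among the compounds with values here, two measured steps bear on this. One is a 5.0-fold lower number from compound 1 to compound 2 (0.69 log units; beyond the scatter), which also brings in a five-membered aromatic ring with 1 hetero atom. The other is a 5.7-fold lower number from compound 1 to compound 3 (0.76 log units; beyond the scatter), which replaces pyridin-3-yl with pyridin-2-yl. Within the data shown here, a modest step of similar size and direction is therefore expected, though no thiophen-2-yl compound has been measured. The estimated step is a 4.6-fold lower number from compound 1 to compound 4 (0.66 log units; beyond the scatter). For compound 4 the estimate is 3500 nM, with an expected range of 1200 nM to 10000 nM.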

Compound 4, half-maximal inhibitory concentration: 1370 nM
For compound 4 the middle estimate is 2.6-fold (0.41 log units) above the measured one; measured number inside the range.
By their numbers in this assay, from the lowest: compound 4; then compounds 3 and 2 (each within the scatter of the next); then compound 1.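

In this assay the change to thiophen-2-yl on this aromatic carbon gives a 12-fold lower number from compound 1 to compound 4 (1.07 log units; beyond the scatter) and is a large step, so a five-membered aromatic ring with one sulfur reaches this level here without chlorine. Thiophen-2-yl also gives a 2.1-fold lower number from compound 3 to compound 4 (0.31 log units; beyond the scatter) against pyridin-2-yl and a 2.4-fold lower number from compound 2 to compound 4 (0.37 log units; beyond the scatter) against the group with two chlorine atoms, which makes compound 4 the strongest inhibitor of the four. Nothing available explains these steps.

From the compounds shown here alone, whether furan-2-yl or thiophen-3-yl would match thiophen-2-yl remains open. So does the effect of a methyl group or a single chlorine on the thiophen-2-yl ring.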